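A few compounds are considered here, and "the series" means these few. Any claim that something is new, unique, unknown or untested is made for them only; others in the source may bear on it.

Measured in an ADME assay on the whole organism with Mus musculus as the target, at a dose of 3 mg/kg by the intravenous route; on this read-out lower numbers stand for lower exposure and higher numbers for higher exposure at the dose given:
- compound 1 `CCC[C@H](C)Nc1ncc2c(-c3ccc(CN4CCCN(C)CC4)cc3)cn([C@H]3CC[C@H](O)CC3)c2n1`: 1360 ng.h/mL
- compound 2 `CCC[C@H](C)Nc1ncc2c(-c3ccc(S(=O)(=O)N4CCN(C)CC4)cc3F)cn([C@H]3CC[C@H](O)CC3)c2n1`: 894 ng.h/mL

Compound 1 holds the top number of this pair at 1360 ng.h/mL, yet compound 2 at 894 ng.h/mL lies within the scatter of it. Compound 3 `CCC[C@H](C)Nc1ncc2c(-c3ccc(CNCCN(CC)CC)cc3)cn([C@H]3CC[C@H](O)CC3)c2n1` keeps the core of compound 1 and changes one place, on a saturated chain carbon bound to an aromatic carbon: (2-(diethylamino)ethyl)amino in place of 4-methyl-1,4-diazepan-1-yl on a saturated chain carbon bound to an aromatic carbon. Going by the values given here, no measured pair isolates a change of this kind, so only a modest downward shift in this assay, not beyond the scatter, is expected. The expected step is a 1.5-fold lower number from compound 1 to compound 3 (0.18 log units; within the scatter). For compound 3 the estimate is 900 ng.h/mL, with an expected range of 350 ng.h/mL to 2200 ng.h/mL.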

Compound 3, area under the concentration-time curve: 608 ng.h/mL
For compound 3 the middle estimate is 1.5-fold (0.17 log units) above the measured one; low and high end bracket the measured number.
By their numbers in this assay, from the lowest: compounds 3, 2 and 1 (each within the scatter of the next, the first and the last beyond it).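

Going by these compounds alone, replacing 4-methyl-1,4-diazepan-1-yl with (2-(diethylamino)ethyl)amino on a saturated chain carbon bound to an aromatic carbon gives a 2.2-fold lower number from compound 1 to compound 3 (0.35 log units; beyond the scatter) in this assay, the first step beyond the scatter at this position. The change removes the seven-membered ring and adds one hydrogen-bond donor at an equal heavy-atom count, and this single pair cannot separate the two. No measurement available here accounts for the step.

Still open, from the compounds shown here alone, is whether the ring or the donor matters more. A morpholin-4-yl group or a dimethylamino-bearing chain at the same place would extend the comparison.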